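The source may report more compounds than this note shows. Statements on the series, on what has been measured and on what is new or still open speak of the compounds shown alone.

Compound 1 `Cc1cc(C(=O)NCc2ccccc2)nn1Cc1cc(Cl)ccc1OCc1ccccc1` and compound 2 `Cc1cc(NC(=O)C2CCCCC2)nn1Cc1cc(Cl)ccc1OCC(C)C` were both tested in an assay on CHO-K1 cells for displacement of a labelled ligand from prostaglandin E2 receptor EP1 subtype (Homo sapiens); a higher number here means a weaker inhibitor, a lower number a stronger inhibitor. Compound 1 gives 39.8 nM, and compound 2 gives 31.6 nM; these two numbers sit within the usual scatter of each other, so neither compound can be called the stronger. Compound 3 `Cc1cc(NC(=O)OCc2ccccc2)nn1Cc1cc(Cl)ccc1OCc1ccccc1` has not yet been measured; it differs from compound 1 in one place: (benzyloxycarbonyl)amino in place of benzylcarbamoyl on an aromatic carbon. Among the measured compounds shown here, no measured pair shows a comparable change, so the step is expected to stay small, near the scatter and perhaps slightly upward, a step of a 1.3-fold higher number from compound 1 to compound 3 (0.10 log units; within the scatter). Compound 3 is therefore estimated at 50 nM, with a range from 15 nM to 160 nM.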

Compound 3, half-maximal inhibitory concentration: 79.4 nM
Compound 3: middle estimate off by 1.6-fold (0.20 log units), on the low side; low and high end bracket the measured number.
By their numbers in this assay, from the lowest: compounds 2, 1 and 3 (each within the scatter of the next, the first and the last beyond it).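

Placing (benzyloxycarbonyl)amino in place of benzylcarbamoyl on this aromatic carbon gives a 2.0-fold higher number from compound 1 to compound 3 (0.30 log units; within the scatter) in this assay. Among the compounds shown here, this is the first one-place comparison at this position. The benzyl end remains while the link to the ring changes, and compound 1 and compound 3 cannot be told apart, so this change of link leaves binding within the usual scatter. On these data alone, whether a free amine or a carboxylic acid on this carbon would also fall in this range remains open. No supporting measurement explains the closeness of these two compounds.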